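Swapping furan for chlorophenyl at one aromatic carbon

The source may report more compounds than this note shows. Statements on the series, on what has been measured and on what is new or still open speak of the compounds shown alone.

Compound 1, `COc1ccc(-c2cc(-c3cc(C(C)C)c(O)cc3C)[nH]c(=O)c2C#N)cc1`, gives 24% in a functional assay for inhibition, tested at 20 ug/mL; a lower number here means a weaker effect, a higher number a stronger effect of the compound at the concentration tested.
Compound 2, `COc1cc(-c2cc(-c3cc(C(C)C)c(O)cc3C)[nH]c(=O)c2C#N)ccc1O`, gives 26% in this assay.
Compound 3, `Cc1cc(O)c(C(C)C)cc1-c1cc(-c2ccco2)c(C#N)c(=O)[nH]1`, gives 26% in this assay.

Compound 3 stands level with compound 2 at the digits shown, the two together the highest of the three, while the step of a number 2 percentage points higher from compound 1 to compound 3 (within the scatter) and the step of no change at the digits printed from compound 2 to compound 3 (within the scatter) both lie within the scatter. Compound 4, `Cc1cc(O)c(C(C)C)cc1-c1cc(-c2ccccc2Cl)c(C#N)c(=O)[nH]1`, differs from compound 3 by 2-chlorophenyl in place of furan-2-yl on an aromatic carbon. All three measured steps vary the group at this same aromatic carbon, and each was small: a number 2 percentage points higher from compound 1 to compound 2 (within the scatter), a number 2 percentage points higher from compound 1 to compound 3 (within the scatter), no change at the digits printed from compound 2 to compound 3 (within the scatter). On that basis the expected step in this assay is none beyond the scatter, no change at the digits printed from compound 3 to compound 4 (within the scatter). Compound 4 is therefore estimated at 26%, with a range of 12% to 42%.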

Compound 4, a percentage reported as inhibition, at one concentration (the size of the read-out at that concentration, not a potency): 12%
Compound 4: the middle estimate sits 14 percentage points above what was measured; the range from low to high includes it.
By their numbers in this assay, from the lowest: compound 4; then compounds 1, 2 and 3 (each within the scatter of the next).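

In this assay, going by these compounds alone, this aromatic carbon proves not to be indifferent to its group, as the earlier compounds alone might have suggested: 2-chlorophenyl gives a number 14 percentage points lower from compound 3 to compound 4 (beyond the scatter) against furan-2-yl, a number 14 percentage points lower from compound 2 to compound 4 (beyond the scatter) against 4-hydroxy-3-methoxyphenyl and a number 12 percentage points lower from compound 1 to compound 4 (beyond the scatter) against 4-methoxyphenyl. Nothing measured here accounts for this drop.

Going by these compounds, whether the lower number goes with the chlorine itself or with its place on the ring stays open; a plain phenyl or a 4-chlorophenyl at this carbon would separate the two. On these data alone, how an amine or a carboxylic acid on that ring would read also stays open.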